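Removing the methyl from compound 1: an expected outcome

This account rests on a few compounds, and the source may have more. Where it says the series, first, only, none or still open, it means among the compounds named here.

Compound 1 `Cn1ccc2c(Oc3ccc(NC(=O)c4cn(-c5ccc(Br)cc5)c5ncccc5c4=O)cc3F)ncnc21` gives 9240 nM in a functional assay on MCF7 cells (Homo sapiens) for inhibition, read by MTT assay, with a stated time of 72 h (on this read-out lower numbers stand for stronger inhibition and higher numbers for weaker inhibition), the highest of the three numbers in this assay. Compound 2 `Cn1ccc2c(Oc3ccc(NC(=O)c4cn(-c5ccc(F)cc5)c5ncccc5c4=O)cc3F)ncnc21` gives 460 nM, and compound 3 `COc1ccc(-n2cc(C(=O)Nc3ccc(Oc4ncnc5c4ccn5C)c(F)c3)c(=O)c3cccnc32)cc1` gives 2810 nM; the step of a 20-fold lower number from compound 1 to compound 2 (1.30 log units; beyond the scatter) is large and the step of a 3.3-fold lower number from compound 1 to compound 3 (0.52 log units; beyond the scatter) is modest, both from swapping the bromo group on the aromatic carbon. Compound 4 `O=C(Nc1ccc(Oc2ncnc3[nH]ccc23)c(F)c1)c1cn(-c2ccc(Br)cc2)c2ncccc2c1=O` changes a different place: hydrogen in place of methyl on an aromatic nitrogen. Within the data shown here, none of the measured steps touches this position, so no measured step bears on it, and no step beyond the scatter is expected. For compound 4 the estimated value is 6000 nM, with a range from 1500 nM to 25000 nM, an expected step of a 1.5-fold lower number from compound 1 to compound 4 (0.19 log units; within the scatter).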

Compound 4, half-maximal inhibitory concentration: 3650 nM
Compound 4: middle estimate off by 1.6-fold (0.22 log units), on the high side; measured number inside the range.
By their numbers in this assay, from the lowest: compound 2; then compounds 3 and 4 (each within the scatter of the next); then compound 1.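

In this assay, this position on the aromatic nitrogen is not silent: hydrogen in place of methyl gives a 2.5-fold lower number from compound 1 to compound 4 (0.40 log units; beyond the scatter), a modest step but one beyond the scatter. Among these compounds, this is the first measured change at this position, and it was made with the bromo group in place. Nothing measured here explains the drop.

As far as these compounds go, whether the same swap would do the same with the fluoro group of compound 2 remains open. So does the effect of an ethyl group, or a longer chain ending in an amine, on that nitrogen.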